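Swapping a side-chain amide for a pyrrolidine

The compounds below may be only part of what the source reports. "The series", "measured", "known", "first", "only" and "open" are said of these compounds alone.

- Compound 1 `Cn1ncc(Cl)c1-c1cc(C(=O)N[C@@H]2CN[C@H](CCn3cncn3)C[C@H]2c2ccc(Cl)c(Cl)c2)oc1Cl`: 1560 nM
- Compound 2 `Cn1ncc(Cl)c1-c1cc(C(=O)N[C@@H]2CN[C@H](CC(=O)NC3CC3)C[C@H]2c2ccc(Cl)c(Cl)c2)oc1Cl`: 580 nM

In a functional assay on OVCAR-8 cells (Homo sapiens) for antiproliferative activity (a higher number here means a weaker inhibitor, a lower number a stronger inhibitor), compound 2 stands lowest of the two measured compounds, at 580 nM. Compound 3 `Cn1ncc(Cl)c1-c1cc(C(=O)N[C@@H]2CN[C@H](CCN3CCCC3)C[C@H]2c2ccc(Cl)c(Cl)c2)oc1Cl` changes the side chain again: (pyrrolidin-1-yl)methyl in place of cyclopropylcarbamoyl on a saturated chain carbon bound to a saturated ring carbon. Here (pyrrolidin-1-yl)methyl takes the place of cyclopropylcarbamoyl. Among the compounds with values here, the only measured step, a 2.7-fold lower number from compound 1 to compound 2 (0.43 log units; beyond the scatter), was modest and involved a different pair of groups, so it suggests a scale but no direction. A change of similar size either way, or none beyond the scatter, is therefore expected in this assay. The central expectation is an estimated 1.0-fold higher number from compound 2 to compound 3 (0.01 log units; within the scatter). For compound 3 the expected value is 600 nM, with an estimated range of 200 nM to 1600 nM.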

Compound 3, half-maximal inhibitory concentration: 1840 nM
Compound 3: the middle estimate sits 3.1-fold (0.49 log units) below what was measured; measured number outside the range, above it.
By their numbers in this assay, from the lowest: compound 2; then compounds 1 and 3 (each within the scatter of the next).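

In this assay the side chain at this position does matter: a 3.2-fold higher number from compound 2 to compound 3 (0.50 log units; beyond the scatter) shows that 2-(pyrrolidin-1-yl)ethyl does not keep the lower number seen with (cyclopropylcarbamoyl)methyl. The pyrrolidine and triazole cannot be told apart, with a 1.2-fold higher number from compound 1 to compound 3 (0.07 log units; within the scatter) as the step between them, so among these three only the cyclopropyl amide stands out. The compounds shown leave open whether that advantage depends on the amide hydrogen or the cyclopropyl ring, which a simple methyl amide or a carboxylic acid on this chain could help separate. No measurement offered here explains the differences.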